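From compound 2 to compound 3: adding carboxymethoxy

The compounds below may be only part of what the source reports. "The series", "measured", "known", "first", "only" and "open" are said of these compounds alone.

Compound 1 `O=C(O)COc1ccc([C@H]2CC[C@]3(CC2)OOC2(O3)C3CC4CC2CC(C3)C4O)cc1` with < 7 mL.min-1.g-1 as a limit
Compound 2 `O=C(O)c1cccc([C@H]2CC[C@]3(CC2)OOC2(O3)C3CC4CC(C3)CC2C4)c1` with 30 mL.min-1.g-1 as a number

Going by the values given here, in an ADME assay on microsomes from liver (Mus musculus) for metabolic stability, using NADPH, with a stated time of 60 min, in the presence of a further agent that is not named here (a lower number here means slower removal, a higher number faster removal of the compound), compound 2 gives 30 mL.min-1.g-1 as the only true number so far. Compound 1 stands at a limit of the assay (< 7 mL.min-1.g-1) and not at a number. Compound 3 `O=C(O)COc1ccc([C@H]2CC[C@]3(CC2)OOC2(O3)C3CC4CC(C3)CC2C4)cc1C(=O)O` has carboxymethoxy in place of hydrogen on an aromatic carbon and awaits measurement. Compound 1 also carries carboxymethoxy, and its limit (< 7 mL.min-1.g-1) leads to an expectation of slower removal. The expected change is a 3.8-fold lower number from compound 2 to compound 3 (0.57 log units; beyond the scatter) in this assay and lies beyond the usual scatter. Compound 3 is estimated at 8 mL.min-1.g-1 (expected range 4 mL.min-1.g-1 to 20 mL.min-1.g-1).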

Compound 3, intrinsic clearance in microsomes: 8 mL.min-1.g-1
Beside the measured number, compound 3's estimate shows no gap at the digits printed; low and high end bracket the measured number.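

In this assay, carboxymethoxy in place of hydrogen on an aromatic carbon, ortho to a carboxy group and para to a large group, gives a 3.8-fold lower number from compound 2 to compound 3 (0.57 log units; beyond the scatter). Going by these compounds alone, compound 3 thus provides the first true number for a compound carrying carboxymethoxy. Compound 1, the other compound with this group, stands at a limit of the assay and not at a number: the limit of < 7 mL.min-1.g-1 in this assay, at which 1 of the 3 values shown sits.

As far as these compounds go, what remains open is whether the step belongs to carboxymethoxy itself or would also appear with another group on this carbon. A methoxy group, an amine or a longer ether chain there could show this.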